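Glucagon receptor series: pyridine core with varied aryl group

The compounds below may be only part of what the source reports. "The series", "measured", "known", "first", "only" and "open" are said of these compounds alone.

Measured compounds:
compound 1 `CCCCCc1c(C(C)C)nc(C(C)C)c(CO)c1-c1ccccc1O` — 500 nM
compound 2 `CCCCCc1c(C(C)C)nc(C(C)C)c(CO)c1-c1cccc(OC)c1` — 48000 nM
compound 3 `CCCCCc1c(C(C)C)nc(C(C)C)c(CO)c1-c1ccccc1N` — 2300 nM

All three share one core and differ only in the aryl group opposite the ring nitrogen. In an assay on CHO cells for inhibition of Glucagon receptor (Homo sapiens) (a higher number here means a weaker inhibitor, a lower number a stronger inhibitor), compound 1 gives 500 nM, the lowest number of the three. Compound 3 stands second of the three: its nearest neighbour is compound 1 (a 4.6-fold higher number from compound 1 to compound 3 (0.66 log units; beyond the scatter)), its furthest is compound 2 (a 21-fold lower number from compound 2 to compound 3 (1.32 log units; beyond the scatter)).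

Compound 4 `CCCCCc1c(C(C)C)nc(C(C)C)c(CO)c1-c1ccc(F)cc1F` has not yet been measured in this assay. It differs from compound 3 in one place: 2,4-difluorophenyl in place of 2-aminophenyl on an aromatic carbon. The 2,4-difluorophenyl brings no hydrogen-bond donor and no acceptor, so the change is a larger one than the amino-for-hydroxy swap of a 4.6-fold higher number from compound 1 to compound 3 (0.66 log units; beyond the scatter). The closest guide is the pair of large steps around compound 2, a 96-fold higher number from compound 1 to compound 2 (1.98 log units; beyond the scatter) and a 21-fold lower number from compound 2 to compound 3 (1.32 log units; beyond the scatter), which show that a ring without a donor on the carbon next to the attachment lands far from compounds 1 and 3.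

A step toward a higher number is therefore expected for this assay, of the size an 8.7-fold higher number from compound 3 to compound 4 (0.94 log units; beyond the scatter). Compound 4 is expected to give about 20000 nM, with a likely range from 4000 nM to 80000 nM.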

Compound 4, half-maximal inhibitory concentration: 11000 nM
Estimate against measurement, compound 4: 1.8-fold (0.26 log units) above, within the range that was stated.
By their numbers in this assay, from the lowest: compound 1; then compound 3; then compound 4; then compound 2.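

In this assay, 2,4-difluorophenyl, with 0 hydrogen-bond donors and 0 hydrogen-bond acceptors, does not put the series at its highest number: the swap for 2-aminophenyl gives a 4.8-fold higher number from compound 3 to compound 4 (0.68 log units; beyond the scatter), while the swap for 3-methoxyphenyl gives a 4.4-fold lower number from compound 2 to compound 4 (0.64 log units; beyond the scatter). The aryl groups therefore do not split into two levels, since the distance to the hydroxy-bearing ring is a 22-fold higher number from compound 1 to compound 4 (1.34 log units; beyond the scatter) and compound 2 still lies further out, so a ring without a hydrogen-bond donor does not fix one value at this position opposite the ring nitrogen. Nothing available on these compounds explains the size of these steps.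

Going by these compounds, the two fluorines are changed together here, so the share of each in the step remains open, and a plain phenyl group or a single fluorine would be needed to divide it. Also open, on these data alone, is whether the low number of compound 1 depends on the hydrogen of its hydroxy group, which a methoxy group in place of that hydroxy, with the rest of the molecule unchanged, would test directly.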